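Pyridin-3-yl in place of bromo: clearance notes

A few compounds are considered here, and "the series" means these few. Any claim that something is new, unique, unknown or untested is made for them only; others in the source may bear on it.

Measured in an ADME assay (liver) for metabolic stability, with Liver microsome (Homo sapiens) as the target, read by LC-MS, using microsomes, with a stated time of 30 min; a higher number here means faster removal of the compound, a lower number slower removal:
- compound 1 `CNC(=O)[C@@H](NC(=O)[C@@](O)(CCCN(Cc1ccc(Br)cc1)NC(=O)[C@@H](NC(=O)OC)C(C)(C)C)Cc1ccccc1)C(C)(C)C`: 180 mL.min-1.g-1
- compound 2 `CNC(=O)[C@@H](NC(=O)[C@@](O)(CCCN(Cc1ccc(-c2ccccc2)cc1)NC(=O)[C@@H](NC(=O)OC)C(C)(C)C)Cc1ccccc1)C(C)(C)C`: > 300 mL.min-1.g-1, a limit of the assay and not a number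

For the measured compounds named here, compound 1 holds the only actual number in this pair, so its standing cannot be ranked further. Compound 3 `CNC(=O)[C@@H](NC(=O)[C@@](O)(CCCN(Cc1ccc(-c2cccnc2)cc1)NC(=O)[C@@H](NC(=O)OC)C(C)(C)C)Cc1ccccc1)C(C)(C)C` shares the core of compound 1 and differs in one place: pyridin-3-yl in place of bromo on an aromatic carbon. Going by the values given here, the one measured step that bears on this, phenyl in place of bromo on the same aromatic carbon, is an at least 1.6-fold higher number from compound 1 to compound 2 (0.22 log units; that floor lies within the scatter). Going by these compounds, only a floor is known for that step, so its true size remains open. Pyridin-3-yl also places a six-membered aromatic ring there, so a small rise in this assay is expected, not clearly beyond the scatter. The estimated change is a 1.2-fold higher number from compound 1 to compound 3 (0.09 log units; within the scatter). For compound 3 the expected value is 220 mL.min-1.g-1, with an estimated range from 110 mL.min-1.g-1 to 350 mL.min-1.g-1.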

Compound 3, intrinsic clearance in microsomes: 63 mL.min-1.g-1
Beside the measured number, compound 3's estimate is 3.5-fold (0.54 log units) above it; measured number below the stated range.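

At this position, on an aromatic carbon of a six-membered aromatic ring of carbon only, the size of the added ring does not settle the outcome in this assay. Pyridin-3-yl in place of phenyl gives an at least 4.7-fold lower number from compound 2 to compound 3 (0.67 log units; beyond the scatter), and pyridin-3-yl in place of bromo gives a 2.9-fold lower number from compound 1 to compound 3 (0.46 log units; beyond the scatter), so the larger group can sit here with a lower number than bromo. Compound 2 carries a limit of the assay and not a number, which leaves the first of these steps as a floor only: the limit of > 300 mL.min-1.g-1 in this assay, at which 1 of the 3 values shown sits.

Open, going by these compounds, is whether the nitrogen's place within the ring matters, as pyridin-2-yl and pyridin-4-yl would show. Also open, on these data alone, is how a pyrimidine ring, or an amine or a carboxylic acid on the added ring, would read in this assay.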